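The source may hold more compounds than are shown below. What is called first, only, known or untested is meant among the compounds shown, and "the series" means these compounds.

Values in a functional assay on A549 cells (Homo sapiens) for antiproliferative activity, read by MTT assay, with a stated time of 48 h (a higher number here means a weaker inhibitor, a lower number a stronger inhibitor), for the measured members of the series:

compound 1 `O=c1ccc2ccc(Oc3no[n+]([O-])c3S(=O)(=O)c3ccccc3)cc2o1` — 8860 nM
compound 2 `Cc1cc(=O)oc2cc(Oc3no[n+]([O-])c3S(=O)(=O)c3ccccc3)ccc12` — 5550 nM
compound 3 `O=C(COc1ccc2ccc(=O)oc2c1)OCCOc1no[n+]([O-])c1S(=O)(=O)c1ccccc1` — > 20000 nM

Compound 1 and compound 2 share a core and differ in one place: methyl in place of hydrogen on an aromatic carbon. In this assay compound 1 gives 8860 nM and compound 2 gives 5550 nM, a step of a 1.6-fold lower number from compound 1 to compound 2 (0.20 log units; within the scatter). Nothing in the data separates the two beyond that scatter, so no ranking of them is made.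

Compound 3 carries a longer linker between the two parts of the molecule. In this assay compound 3 reaches only a limit of the assay, > 20000 nM, and no number is known for it (the limit of > 20000 nM in this assay, at which 1 of the 3 values shown sits). How the core of compound 3 differs from the core of compound 1 is not broken down here.

Compound 4 `Cc1cc(=O)oc2cc(OCC(=O)OCCOc3no[n+]([O-])c3S(=O)(=O)c3ccccc3)ccc12` has not been measured. It differs from compound 3 by methyl in place of hydrogen on an aromatic carbon, which is the same change as that from compound 1 to compound 2, made at the same place on the ring. Since that change moved the value only within the scatter, the expected step is a number no higher from compound 3 to compound 4 (the limit leaves the size open), and this rests on a 1.6-fold lower number from compound 1 to compound 2 (0.20 log units; within the scatter). Because compound 3 gives only a limit (the limit of > 20000 nM in this assay, at which 1 of the 3 values shown sits), compound 4 is expected to sit at or near that limit as well. For compound 4 the estimated value in this assay is 20000 nM, expected to fall between 9000 nM and 45000 nM, with a real chance that only a limit is reported again.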

Compound 4, half-maximal inhibitory concentration: 6920 nM
The estimate for compound 4 lay 2.9-fold (0.46 log units) above the measured number, outside the stated range (below it).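

In this assay, methyl in place of hydrogen on an aromatic carbon of the core with the longer linker gives an at least 2.8-fold lower number from compound 3 to compound 4 (0.46 log units; beyond the scatter), a step beyond the scatter, whereas a 1.6-fold lower number from compound 1 to compound 2 (0.20 log units; within the scatter) stays within the scatter on the core of compound 1. Read together, the two steps do not show that the change does more on one core than on the other, and they do not show that it carries over with a fixed size: the same change on two cores in this assay, a 1.6-fold lower number (0.20 log units; within the scatter) from compound 1 to compound 2 and an at least 2.8-fold lower number (0.46 log units; beyond the scatter) from compound 3 to compound 4; the limit leaves it open whether they differ The true size of the newer step also stays unknown, since compound 3 gives a limit of the assay and not a number: the limit of > 20000 nM in this assay, at which 1 of the 4 values shown sits.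

As far as these compounds go, only hydrogen and methyl appear at this place on the ring, so it remains open how an ethyl group, a chlorine atom or a methoxy group would read there. From the compounds shown here alone, it is also open whether the same change gives a step of similar size with a longer chain in the linker, or with an amide in place of the ester in that linker.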